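The source may hold more compounds than are shown below. What is called first, only, known or untested is meant among the compounds shown, and "the series" means these compounds.

Compound 2 `C#Cc1ccc2ccn(CCN3CCCN(C)CC3)c2c1` is the point of departure. Among the measured compounds shown here, in an assay on HEK293 cells for binding affinity to 5-hydroxytryptamine receptor 7 (Homo sapiens), read by radioligand binding (a higher number here means a weaker inhibitor, a lower number a stronger inhibitor), compound 2 gives 140 nM, the lowest of the two numbers so far; its nearest neighbour is compound 1 `CN1CCCN(CCn2ccc3ccc(F)cc32)CC1`, which in this assay gives 288 nM. For the measured compounds named here, the single measured step, a 2.1-fold lower number from compound 1 to compound 2 (0.31 log units; beyond the scatter), is the only guide available. Compound 3 `CC(C)c1ccc2ccn(CCN3CCCN(C)CC3)c2c1` has not yet been measured. It differs from compound 2 in one place: isopropyl in place of ethynyl on an aromatic carbon. Going by the values given here, the measured step exchanged fluoro for ethynyl on an aromatic carbon of the shared core and was modest; no measured step exchanges ethynyl for an alkyl group, so the bearing of the known step is indirect. It shows that a change at such a carbon can move the number, but only modestly. A step of similar or smaller size is therefore expected in this assay, in either direction, quite possibly within the scatter. Compound 3 is expected to give 200 nM, with a range from 80 nM to 500 nM. This estimate amounts to a step of a 1.4-fold higher number from compound 2 to compound 3 (0.15 log units; within the scatter).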

Compound 3, inhibition constant: 145 nM
Estimate against measurement, compound 3: 1.4-fold (0.14 log units) above, within the range that was stated.
By their numbers in this assay, from the lowest: compounds 2, 3 and 1 (each within the scatter of the next, the first and the last beyond it).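

In this assay the exchange of ethynyl for isopropyl gives a 1.0-fold higher number from compound 2 to compound 3 (0.02 log units; within the scatter), so among the compounds shown the triple bond of compound 2 is not required for a reading of this size, and a branched group of 3 carbon atoms serves as well. Against fluoro, isopropyl gives a 2.0-fold lower number from compound 1 to compound 3 (0.30 log units; within the scatter), which lies within the scatter, whereas ethynyl gives a 2.1-fold lower number from compound 1 to compound 2 (0.31 log units; beyond the scatter), which lies beyond it; these two steps are nearly the same size, so that difference in how they are printed does not separate ethynyl from isopropyl. Nothing measured here explains why these two groups read alike.

Going by these compounds, it remains open whether an amine, a carboxylic acid or a methoxy group at this carbon would fall in the same narrow span, and whether a longer chain or a tert-butyl group would still be accommodated without a change in the number. The compounds shown also leave open whether ethynyl and isopropyl would match each other at any other carbon of the shared core.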